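The source may report more compounds than this note shows. Statements on the series, on what has been measured and on what is new or still open speak of the compounds shown alone.

Measured so far:
- Compound 1 `O=C(CCCCCC(NC(=O)c1cccnc1)C(=O)NCc1ccccc1)NO`: 24000 nM
- Compound 2 `CC(C)CCNC(=O)C(CCCCCC(=O)NO)NC(=O)c1cccnc1`: 12000 nM
- Compound 3 `O=C(/C=C/c1ccccc1)N[C@@H](CCCCCC(=O)NO)C(=O)NCc1ccccc1`: 4010 nM

All three share a core that ends in a hydroxamic acid, and all were tested in a functional assay on NFF cells (Homo sapiens) for antiproliferative activity; a higher number here means a weaker inhibitor, a lower number a stronger inhibitor. Compound 3 gives the lowest number of the three: compound 2 sits a 2.0-fold lower number from compound 1 to compound 2 (0.30 log units; within the scatter), but the gap from compound 2 down to compound 3 lies beyond the scatter, and the gap from compound 1 to compound 3 is wider still. The cap on the amide nitrogen, then, has so far moved the number more than the group on the other end.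

Compound 4 `O=C(CCCCC[C@H](NC(=O)c1cc2c(Br)cccc2[nH]1)C(=O)NCc1ccccc1)NO` keeps everything of compound 3 except that cap: 4-bromo-1H-indol-2-yl in place of 2-phenylethenyl on a carbonyl carbon. Among the measured compounds shown here, no measured step tests this exchange directly. For the measured compounds named here, the only step on record, a 2.0-fold lower number from compound 1 to compound 2 (0.30 log units; within the scatter), concerns the opposite end of the molecule and is within the scatter. What compound 1 and compound 3 show is that a change of cap can shift the number well beyond the scatter, but the new cap of compound 4 has no measured relative here.

With that caution, compound 4 is expected to land somewhat lower than compound 3, a step of a 2.0-fold lower number from compound 3 to compound 4 (0.30 log units; within the scatter), which may well fall within the scatter. The estimate for compound 4 in this assay is 2000 nM, with a range from 500 nM to 8000 nM.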

Compound 4, half-maximal inhibitory concentration: 1940 nM
Compound 4: middle estimate off by 1.0-fold (0.01 log units), on the high side; measured number inside the range.
By their numbers in this assay, from the lowest: compound 4; then compound 3; then compounds 2 and 1 (each within the scatter of the next).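

In this assay, among the compounds shown here, putting 4-bromo-1H-indol-2-yl in place of 2-phenylethenyl on the carbonyl carbon gives the first step that can be read directly for a change at this position: a 2.1-fold lower number from compound 3 to compound 4 (0.32 log units; beyond the scatter), modest but beyond the scatter. For the compounds shown here, the earlier compounds showed only that compounds with different caps could give different numbers, and those compounds also differed elsewhere, so the effect of the cap alone could not be separated. This position accepts a larger group with two aromatic rings, a bromine and a hydrogen-bond donor in place of one aromatic ring and a double bond, and the number still falls rather than rises. Nothing available here explains why the number falls.

The compounds shown leave open which part of the new cap accounts for the step, a question that 4-chloro-1H-indol-2-yl or the same cap with a hydrogen in place of the bromine could help answer. They also leave open whether this cap gives a similar step when the benzyl group on the other amide is replaced by a longer chain or an amine.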